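The source may report more compounds than this note shows. Statements on the series, on what has been measured and on what is new or still open speak of the compounds shown alone.

Series notes. Compound 1 `O=c1oc2ccccc2n1Cc1nc(-c2cccc(Cl)c2)no1` gives 2100 nM in an in vitro functional assay on HEK293-A cells for negative allosteric modulation of metabotropic glutamate receptor 5 (Homo sapiens), read by FLIPR and calcium flux; on this read-out lower numbers stand for stronger inhibition and higher numbers for weaker inhibition. Compound 2 `Cc1ccc(N2CC(c3nc(-c4cccc(Cl)c4)no3)CC2=O)cc1C` returns only a limit in this assay, namely > 10000 nM. That is the limit of > 10000 nM in this assay, at which 1 of the 2 values shown sits, so compound 2 has no number of its own and sits at the weak end of what has been measured; its gap to compound 1 cannot be sized. Compound 3 `Cc1ccc(N2CC(c3nc(-c4cccc(Cl)c4)no3)CC2=O)cc1` is the next entry. It differs from compound 2 by hydrogen in place of methyl on an aromatic carbon. Within the data shown here, no pair of measured compounds shows this change, so its size is unknown from the data. On what the two measured values show, the change from 3,4-dimethylphenyl to 4-methylphenyl is expected to move the value in this assay little, no step beyond the scatter. The expected step is a number no higher from compound 2 to compound 3 (the limit leaves the size open). For compound 3 the estimate is 10000 nM, in the range 3000 nM to 30000 nM, with a limit rather than a number the likelier outcome.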

Compound 3, half-maximal inhibitory concentration: > 10000 nM
Compound 3: no number, only a limit; the forecaster's own chance of this, stated with the estimate: 60%; the middle value sits exactly at the limit.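

In this assay, compound 2 and compound 3 are both limits and not numbers, so no step can be read between them: the limit of > 10000 nM in this assay, at which 2 of the 3 values shown sit.

On these data alone, whether hydrogen in place of methyl on an aromatic carbon changes inhibition at all, and in which direction, stays open.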